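The source may report more compounds than this note shows. Statements on the series, on what has been measured and on what is new or still open speak of the compounds shown alone.

Working notes on the series.

Compound 1 `COc1ccc(/C=C/S(=O)(=O)Cc2ccc(OC)c(N)c2)cc1` gives 2500 nM in a functional assay on DU-145 cells (Homo sapiens) for cytotoxicity, read by trypan blue exclusion, with a stated time of 96 h; a lower number here means a stronger inhibitor, a higher number a weaker inhibitor. Compound 3 `COc1ccc(/C=C/S(=O)(=O)Cc2ccc(OC)c(N)c2)c(OC)c1` differs from it by methoxy in place of hydrogen on an aromatic carbon and gives 500 nM in this assay, a step of a 5.0-fold lower number from compound 1 to compound 3 (0.70 log units; beyond the scatter). Compound 2 `COc1ccc(CS(=O)(=O)/C=C/c2c(OC)cccc2OC)c([N+](=O)[O-])c1` gives 50000 nM in this assay; the difference between the core of compound 2 and the core of compound 1 is not broken down here. Compound 4 `COc1cc(OC)c(/C=C/S(=O)(=O)Cc2ccc(OC)cc2[N+](=O)[O-])c(OC)c1` is unmeasured and differs from compound 2 by methoxy in place of hydrogen on an aromatic carbon. This is the same kind of change as between compound 1 and compound 3, not the same: there the place was ortho to a large group and meta to a methoxy group, here it is meta to two methoxy groups and para to a large group. For compound 4 a step of a 3.3-fold lower number from compound 2 to compound 4 (0.52 log units; beyond the scatter) is expected, resting on compound 1 and compound 3 and their step of a 5.0-fold lower number from compound 1 to compound 3 (0.70 log units; beyond the scatter), with allowance for the changed place. Compound 4 is estimated at 15000 nM, between 4000 nM and 60000 nM.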

Compound 4, half-maximal inhibitory concentration: 20000 nM
Beside the measured number, compound 4's estimate is 1.3-fold (0.12 log units) below it; the measured number falls inside the stated range.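

In this assay methoxy in place of hydrogen on an aromatic carbon gives a 2.5-fold lower number from compound 2 to compound 4 (0.40 log units; beyond the scatter) on a second core, the same direction as on the first. The sizes of the two steps cannot be told apart, so the change carries across these two cores without a measurable difference: the same change on two cores in this assay, a 5.0-fold lower number (0.70 log units; beyond the scatter) from compound 1 to compound 3 and a 2.5-fold lower number (0.40 log units; beyond the scatter) from compound 2 to compound 4, 2.0-fold (0.30 log units) apart, within the scatter of two such steps. This rests on two pairs only, with the methoxy in a different place on each core, and it does not show that the step holds on other cores or separate the effect of the core from that of the place.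

Open, as far as these compounds go, is whether ethoxy, hydroxy or fluorine in the same places would give steps of similar size. Also open, from the compounds shown here alone, is whether methoxy at other places on these cores would do so.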